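A few compounds are considered here, and "the series" means these few. Any claim that something is new, unique, unknown or untested is made for them only; others in the source may bear on it.

In a functional assay on MCF7 cells (Homo sapiens) for antiproliferative activity, read by sulforhodamine B assay, with a stated time of 48 h (a higher number here means a weaker inhibitor, a lower number a stronger inhibitor), compound 1 `O=C1NCCN1c1ccc(S(=O)(=O)Nc2ccc(F)cc2)cc1` gives 690 nM, while compound 2 `O=C1NCCN1c1ccc(S(=O)(=O)Nc2ccc(Cl)cc2)cc1` gives 170 nM. Compound 2 therefore holds the lower number of the pair and is the stronger inhibitor of the two. Compound 3 `Cc1ccc(C)c(NS(=O)(=O)c2ccc(N3CCNC3=O)cc2)c1` keeps the shared core but exchanges the whole group on the sulfonamide nitrogen: 2,5-dimethylphenyl in place of 4-chlorophenyl on a sulfonamide nitrogen. Put simply, it has 2,5-dimethylphenyl in place of 4-chlorophenyl on a sulfonamide nitrogen. Within the data shown here, only one measured step bears on this change, and it is a modest one: a 4.1-fold lower number from compound 1 to compound 2 (0.61 log units; beyond the scatter). That step shows that swapping a single atom in this group can move the number beyond the scatter, but it compares two halogens only. Among the measured compounds shown here, no measured compound carries methyl groups, so the evidence is thin. For the measured compounds named here, compound 2 has the lower number so far, so a move upward seems somewhat more likely than a further drop, and a moderate size seems a fair expectation. The estimated step is a 1.8-fold higher number from compound 2 to compound 3 (0.25 log units; within the scatter). For compound 3 the expected value is 300 nM, with an estimated range from 70 nM to 1200 nM.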

Compound 3, half-maximal inhibitory concentration: 48 nM
Estimate against measurement, compound 3: 6.3-fold (0.80 log units) above; measured number outside the range, below it.
By their numbers in this assay, from the lowest: compound 3; then compound 2; then compound 1.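

In this assay the move to 2,5-dimethylphenyl on the sulfonamide nitrogen gives a 3.5-fold lower number from compound 2 to compound 3 (0.55 log units; beyond the scatter) and, measured against the fluorinated partner, a 14-fold lower number from compound 1 to compound 3 (1.16 log units; beyond the scatter), which places compound 3 lowest of the three. The earlier pair compared only two halogens on an otherwise identical ring, whereas this result shows that the group on this nitrogen needs no halogen at all for a low number, and that an all-carbon group with one more heavy atom than 4-chlorophenyl is accepted here. Nothing shown explains why this exchange lowers the number.

This exchange removes the chlorine and adds two methyl groups at different ring positions in a single step, so the compounds shown cannot say whether one methyl group alone would give the same drop or whether both are needed. They also leave open how this position would respond to a methoxy group, an amine or a carboxylic acid on the ring, or to a saturated cyclohexyl ring in place of the aromatic one.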